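Series notes: aryl swap on the four-membered ring carbon

The source may report more compounds than this note shows. Statements on the series, on what has been measured and on what is new or still open speak of the compounds shown alone.

Values from a functional assay on MCF7 cells (Homo sapiens) for antiproliferative activity, read by MTT assay, with stated times of 24 h and 72 h (on this read-out higher numbers stand for weaker inhibition and lower numbers for stronger inhibition), for the two measured compounds:
- compound 1 `COc1cc(N2C(=O)[C@@H](Oc3ccccc3)[C@H]2c2cccc3ccccc23)cc(OC)c1OC`: 53000 nM
- compound 2 `COc1cc(N2C(=O)[C@@H](Oc3ccccc3)[C@H]2c2ccc(S(C)(=O)=O)cc2)cc(OC)c1OC`: 62000 nM

Compound 2 and compound 1 are separated only by a 1.2-fold higher number from compound 1 to compound 2 (0.07 log units; within the scatter), a step that the scatter covers, so the two numbers stand together rather than apart; of the two, compound 2 carries the numerically higher entry, but nothing beyond the scatter distinguishes it from compound 1.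

Compound 3 `COc1ccc([C@@H]2[C@H](Oc3ccccc3)C(=O)N2c2cc(OC)c(OC)c(OC)c2)cc1N` is the next member. Its change from compound 2 is 3-amino-4-methoxyphenyl in place of 4-(methylsulfonyl)phenyl on a saturated ring carbon. Among the measured compounds shown here, the one measured step that bears on this place is the step from compound 1 to compound 2, in which one aryl group replaced another on the same saturated ring carbon and the number moved by a 1.2-fold higher number from compound 1 to compound 2 (0.07 log units; within the scatter) only. With a single comparison at this position, and that one within the scatter, no step beyond the scatter is expected for the present exchange; the estimate for compound 3 therefore amounts to a 1.1-fold lower number from compound 2 to compound 3 (0.05 log units; within the scatter). Compound 3 is estimated at 55000 nM in this assay, with a range from 20000 nM to 150000 nM.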

Compound 3, half-maximal inhibitory concentration: 12200 nM
Compound 3: the middle estimate sits 4.5-fold (0.65 log units) above what was measured, outside the stated range (below it).
By their numbers in this assay, from the lowest: compound 3; then compounds 1 and 2 (each within the scatter of the next).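

On the saturated ring carbon of the four-membered ring, the aryl group does move the number in this assay: 3-amino-4-methoxyphenyl in place of 4-(methylsulfonyl)phenyl gives a 5.1-fold lower number from compound 2 to compound 3 (0.71 log units; beyond the scatter) and the same group in place of naphthalen-1-yl gives a 4.3-fold lower number from compound 1 to compound 3 (0.64 log units; beyond the scatter) as well. The exchange between compound 1 and compound 2 had left the position looking indifferent to the aryl group, whereas compound 3 now stands apart from both on the side of stronger inhibition, with the phenoxy group and the rest of the shared core unchanged. Nothing at hand accounts for the size of these steps.

The compounds shown do not separate the amino group of 3-amino-4-methoxyphenyl from its methoxy group, nor do they tell whether the step comes from the group that enters, the group that leaves, or both. A hydroxyl, an acetamide or a dimethylamino group in place of that amino group would bear directly on this question, as would a plain phenyl at the same ring carbon.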